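The compounds below may be only part of what the source reports. "The series", "measured", "known", "first", "only" and "open" are said of these compounds alone.

Measured so far:
- compound 1 `Cc1cc(C(F)(F)F)ccc1-c1cc2cnn([C@@H](CC(C)C)c3ccc(C(=O)NCCC(=O)O)cc3)c2cc1C`: 16.9 h
- compound 2 `Cc1cc(C(F)(F)F)ccc1-c1cc2cn([C@@H](CC(C)C)c3ccc(C(=O)NCCC(=O)O)cc3)nc2cc1C`: 20.2 h

In an ADME assay on the whole organism (Canis lupus familiaris) for metabolic stability, at a dose of 10 mg/kg by the oral route (on this read-out lower numbers stand for a shorter-lived compound and higher numbers for a longer-lived compound), compound 1 gives 16.9 h and compound 2 gives 20.2 h. These two numbers lie within the scatter of each other, so neither compound can be ranked over the other.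

Next in the series is compound 3 `Cc1cc2c(cnn2[C@@H](CC(C)C)c2ccc(C(=O)NCCC(=O)O)cc2)cc1-c1ccc(C(F)(F)F)cc1Cl`, which differs from compound 1 in one place: chloro in place of methyl on an aromatic carbon. This puts chloro in place of methyl on an aromatic carbon, turning 2-methyl-4-(trifluoromethyl)phenyl into 2-chloro-4-(trifluoromethyl)phenyl. Among the measured compounds shown here, no measured pair shows this change, so the expectation starts from compound 1 at 16.9 h. No shift beyond the scatter is expected in this assay. The estimated step is a 1.1-fold higher number from compound 1 to compound 3 (0.05 log units; within the scatter). For compound 3 the expected value is 19 h, with an estimated range of 10 h to 35 h.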

Compound 3, half-life: 18.9 h
The estimate for compound 3 lay 1.0-fold (0.00 log units) above the measured number, and the stated range covers the measured number.
By their numbers in this assay, from the lowest: compounds 1, 3 and 2 (each within the scatter of the next).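

In this assay, chloro in place of methyl on an aromatic carbon ortho to a large group gives a first single-place read on this aryl group (a 1.1-fold higher number from compound 1 to compound 3 (0.05 log units; within the scatter)), and the two compounds cannot be told apart at this position. Compound 1 and compound 2 both carry 2-methyl-4-(trifluoromethyl)phenyl, so they said nothing about this substituent. Nothing available accounts for the result.

Open, from the compounds shown here alone, is whether the same aromatic carbon keeps the half-life in this range with a different group, such as fluoro, methoxy or a nitrile, or whether one of these gives a step beyond the scatter. Also open, going by these compounds, is whether chloro in place of methyl reads the same on the core of compound 2, and whether the trifluoromethyl group can give way to a chloro or a methoxy.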